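Quaternary ammonium tail variation on the COL1A1 promoter series

A few compounds are considered here, and "the series" means these few. Any claim that something is new, unique, unknown or untested is made for them only; others in the source may bear on it.

Measured so far in an assay on LX2 cells for inhibition of COL1A1 promoter (Homo sapiens), read by a luciferase reporter, with a stated time of 24 h, tested at 50 uM; on this read-out higher numbers stand for a stronger effect at the one concentration tested and lower numbers for a weaker effect:
compound 1 `Cc1cc(OCCCCCCC[N+]23CCN(CC2)CC3)cc(-n2cc(C(=O)Nc3cc(F)cc(F)c3)c(=O)c3ccc(N(C)C)nc32)c1` gives 5.52%
compound 2 `Cc1cc(OCCCCCCC[N+]2(C)CCCCC2)cc(-n2cc(C(=O)Nc3cc(F)cc(F)c3)c(=O)c3ccc(N(C)C)nc32)c1` gives 79.7%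
compound 3 `Cc1cc(OCCCCCCC[n+]2ccccc2)cc(-n2cc(C(=O)Nc3cc(F)cc(F)c3)c(=O)c3ccc(N(C)C)nc32)c1` gives 61%

Compound 3 sits second highest of the three numbers in this assay; its nearest neighbour is compound 2, and compound 1 lies furthest from it. The two steps from compound 1 were both large: a number 74.2 percentage points higher from compound 1 to compound 2 (beyond the scatter) and a number 55.5 percentage points higher from compound 1 to compound 3 (beyond the scatter). Between the two single-ring tails the step is smaller, a number 18.7 percentage points lower from compound 2 to compound 3 (beyond the scatter), yet still beyond the scatter.

Compound 4 `CC[N+]1(CCCCCCCOc2cc(C)cc(-n3cc(C(=O)Nc4cc(F)cc(F)c4)c(=O)c4ccc(N(C)C)nc43)c2)CCCC1` carries the change (a group of 7 heavy atoms (6 carbon, 1 nitrogen; one five-membered non-aromatic ring with 1 hetero atom) in place of a group of 6 heavy atoms (5 carbon, 1 nitrogen; one six-membered aromatic ring with 1 hetero atom), on a saturated chain carbon, seven bonds along the chain from an oxygen on an aromatic ring). Within the data shown here, the step that bears most directly on it is the one from compound 2 to compound 3, where a non-aromatic six-membered ring with one nitrogen gave way to an aromatic one and the number fell modestly. Compound 4 returns to a non-aromatic ring bearing a positive nitrogen, so an increase of about that size in this assay is expected, roughly a number 11 percentage points higher from compound 3 to compound 4 (beyond the scatter). Compound 4 is therefore estimated at 72%, with a range from 55% to 88%.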

Compound 4, a percentage reported as inhibition, at one concentration (the size of the read-out at that concentration, not a potency): 73.2%
For compound 4 the middle estimate is 1.2 percentage points below the measured one; the range from low to high includes it.
By their numbers in this assay, from the lowest: compound 1; then compound 3; then compounds 4 and 2 (each within the scatter of the next).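

In this assay the five-membered non-aromatic ring tail on the saturated chain carbon reads level with the six-membered non-aromatic ring tail, a number 6.5 percentage points lower from compound 2 to compound 4 (within the scatter), so this position accepts the change in ring size and the groups on the charged nitrogen that come with it. The second step, a number 12.2 percentage points higher from compound 3 to compound 4 (beyond the scatter), places both non-aromatic single-ring tails above the aromatic ring tail, while a number 67.7 percentage points higher from compound 1 to compound 4 (beyond the scatter) shows that compound 1 goes against any general favour for non-aromatic rings, as its tail with two six-membered non-aromatic rings stays far lower. No measurement on hand accounts for these differences.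

As far as these compounds go, whether a trimethylammonium group or an uncharged tertiary amine would hold the read-out at this position stays open. So does the effect of a shorter or longer chain carrying the five-membered ring tail.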